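Replacing the five-membered ring with 1-acetylpiperidin-4-yl

This account rests on a few compounds, and the source may have more. Where it says the series, first, only, none or still open, it means among the compounds named here.

Compound 1, `C[C@@H](NS(C)(=O)=O)c1cncc(N2C(=O)c3ccc(Cl)cc3C2(C)C)c1`, gives 8 nM in an assay on cells for inhibition of cytochrome P450 11B2, mitochondrial (Homo sapiens), read by HTRF; a lower number here means a stronger inhibitor, a higher number a weaker inhibitor. Compound 2, `CC(=O)N1CC[C@H](Oc2cncc(N3C(=O)c4ccc(Cl)cc4C3(C)C)c2)C1`, gives 7 nM in this assay; the step of a 1.1-fold lower number from compound 1 to compound 2 (0.06 log units; within the scatter) is within the scatter, so compound 2 stands on the same footing as compound 1 rather than apart from it. Compound 3, `CC(=O)N1CCC(c2cncc(N3C(=O)c4ccc(Cl)cc4C3(C)C)c2)CC1`, differs from compound 2 in one place: a group of 9 heavy atoms (7 carbon, 1 nitrogen, 1 oxygen; one six-membered non-aromatic ring with 1 hetero atom) in place of a group of 9 heavy atoms (6 carbon, 1 nitrogen, 2 oxygen; one five-membered non-aromatic ring with 1 hetero atom), on an aromatic carbon. Among the measured compounds shown here, only one measured step exists for comparison, the one from compound 1 to compound 2, and it changed the same position without moving the number beyond the scatter. That step swapped a chain for a ring, whereas here one ring replaces another, so it bears on the present change only loosely. Compound 3 is therefore expected to give 10 nM in this assay, within a range of 4 nM to 25 nM. This estimate means a step of a 1.4-fold higher number from compound 2 to compound 3 (0.15 log units; within the scatter), expected to stay within the scatter.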

Compound 3, half-maximal inhibitory concentration: 5 nM
For compound 3 the middle estimate is 2.0-fold (0.30 log units) above the measured one, within the range that was stated.
By their numbers in this assay, from the lowest: compounds 3, 2 and 1 (each within the scatter of the next).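

In this assay, replacing the five-membered ring with 1-acetylpiperidin-4-yl gives a 1.4-fold lower number from compound 2 to compound 3 (0.15 log units; within the scatter) as a step, so this position on the aromatic ring accepts either ring. The new group carries 1 hydrogen-bond acceptor against 2 in the group it replaces and brings no defined stereocentre, yet neither difference moves the number beyond the scatter. The comparison with the open chain of compound 1 gives a 1.6-fold lower number from compound 1 to compound 3 (0.20 log units; within the scatter) as its step and also stays within the scatter, so all three groups stand on the same footing in this assay.

Going by these compounds, whether a free amine, a carboxylic acid or a longer chain at this position would stay in the same range remains open. No supporting measurement is available to explain why these groups give such similar numbers.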